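The source may report more compounds than this note shows. Statements on the series, on what has been measured and on what is new or still open speak of the compounds shown alone.

Values in a functional assay on 1321-N1 cells for agonist activity at P2Y purinoceptor 6 (Homo sapiens), read by scintillation counting and inositol phosphate accumulation; a higher number here means that more compound is needed for the effect, a lower number that less compound is needed:
compound 1, `O=c1[nH]/c(=N\OCCCc2ccc(Br)cc2)ccn1[C@@H]1O[C@H](COP(=O)(O)OP(=O)(O)OP(=O)(O)O)[C@@H](O)[C@H]1O`: 225 nM
compound 2, `COc1ccc(CCCO/N=c2/ccn([C@@H]3O[C@H](COP(=O)(O)OP(=O)(O)OP(=O)(O)O)[C@@H](O)[C@H]3O)c(=O)[nH]2)cc1`: 277 nM

Compound 2 stands beside compound 1 in this assay; the only step shown, a 1.2-fold higher number from compound 1 to compound 2 (0.09 log units; within the scatter), lies within the scatter, so nothing separates the two numbers. Compound 3, `O=c1[nH]/c(=N\OCCCc2cccnc2)ccn1[C@@H]1O[C@H](COP(=O)(O)OP(=O)(O)OP(=O)(O)O)[C@@H](O)[C@H]1O`, differs from compound 2 in one place: pyridin-3-yl in place of 4-methoxyphenyl on a saturated chain carbon, three bonds along the chain from an oxygen on an unsaturated carbon. For the measured compounds named here, no measured step covers a ring with a hetero atom entering here; so far the one change made on this aryl group has not moved the number. Compound 3 is therefore expected to stay near compound 2, with an estimated step of a 1.3-fold higher number from compound 2 to compound 3 (0.10 log units; within the scatter), giving 350 nM in the range 150 nM to 900 nM.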

Compound 3, half-maximal effective concentration: 2950 nM
Compound 3: middle estimate off by 8.4-fold (0.93 log units), on the low side, and the stated range ends below it.
By their numbers in this assay, from the lowest: compounds 1 and 2 (each within the scatter of the next); then compound 3.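

The aryl group at this position is not indifferent in this assay: pyridin-3-yl in place of 4-methoxyphenyl brings an 11-fold higher number from compound 2 to compound 3 (1.03 log units; beyond the scatter) and pyridin-3-yl in place of 4-bromophenyl brings a 13-fold higher number from compound 1 to compound 3 (1.12 log units; beyond the scatter). The tolerance seen between the two substituted phenyl compounds does not extend to this ring with a hetero atom. Nothing measured here bears on why the number rises.

The compounds shown cannot separate the effect of the ring nitrogen from the loss of the methoxy or bromo group. Plain phenyl and a methoxy-substituted pyridin-3-yl at this place would pull those two changes apart.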